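From a Chlorinated Chain to a Sulfonamide Arm

This account rests on a few compounds, and the source may have more. Where it says the series, first, only, none or still open, it means among the compounds named here.

Measured compounds in a functional assay on MCF7 cells (Homo sapiens) for antiproliferative activity, read by MTT assay, with a stated time of 72 h; on this read-out lower numbers stand for stronger inhibition and higher numbers for weaker inhibition:
compound 1, `CCCCCCCCCCc1cn(C[C@H](O)[C@H]2OC(=O)C(OCc3ccccc3)=C2OCc2ccccc2)nn1`: 80 nM
compound 2, `Cc1ccc(-c2cn(C[C@H](O)[C@H]3OC(=O)C(OCc4ccccc4)=C3OCc3ccccc3)nn2)cc1`: > 100000 nM, a limit of the assay rather than a number
compound 3, `O=C1O[C@H]([C@@H](O)Cn2cc(CCCCl)nn2)C(OCc2ccccc2)=C1OCc1ccccc1`: 24500 nM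

Compound 3 holds the higher of the two numbers given; its nearest neighbour is compound 1, and the gap is a 310-fold higher number from compound 1 to compound 3 (2.49 log units; beyond the scatter). Compound 2 sits at a limit, (the limit of > 100000 nM in this assay, at which 1 of the 3 values shown sits), so its step to compound 3 reads an at least 4.0-fold lower number from compound 2 to compound 3 (0.61 log units; beyond the scatter).

Compound 4, `Cc1ccc(S(=O)(=O)NCc2cn(C[C@H](O)[C@H]3OC(=O)C(OCc4ccccc4)=C3OCc3ccccc3)nn2)cc1`, has not been measured. It differs from compound 3 by ((4-methylphenyl)sulfonyl)amino in place of 2-chloroethyl on a saturated chain carbon bound to an aromatic carbon. Going by the values given here, two measured steps bear on this. Replacing the decyl chain of compound 1 with a shorter chlorinated chain gave a 310-fold higher number from compound 1 to compound 3 (2.49 log units; beyond the scatter), and placing a 4-methylphenyl directly on the aromatic carbon gave an at least 1200-fold higher number from compound 1 to compound 2 (3.09 log units; beyond the scatter). Compound 4 brings the 4-methylphenyl ring back, though at the end of a saturated linker, and drops the remaining chlorinated chain. Against that background the step is expected to be a 1.4-fold higher number from compound 3 to compound 4 (0.15 log units; within the scatter), upward rather than downward. Compound 4 is therefore estimated at 35000 nM, within a range from 6000 nM to 100000 nM, in this assay.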

Compound 4, half-maximal inhibitory concentration: 6400 nM
Beside the measured number, compound 4's estimate is 5.5-fold (0.74 log units) above it, and the stated range covers the measured number.
By their numbers in this assay, from the lowest: compound 1; then compound 4; then compound 3. At a limit, above all of these: compound 2.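

In this assay, ((4-methylphenyl)sulfonyl)amino in place of 2-chloroethyl on a saturated chain carbon bound to an aromatic carbon gave a 3.8-fold lower number from compound 3 to compound 4 (0.58 log units; beyond the scatter), showing that this position accepts a much larger arm carrying an aromatic ring without losing activity relative to the chlorinated chain. The 4-methylphenyl ring is therefore not excluded from this part of the molecule, as the arm of compound 4 compares with the directly attached ring of compound 2 as an at least 15-fold lower number from compound 2 to compound 4 (1.19 log units; beyond the scatter), and that comparison rests on a limit rather than a number: the limit of > 100000 nM in this assay, at which 1 of the 4 values shown sits. Even so, the arm does not replace the long alkyl chain, since the change gave an 80-fold higher number from compound 1 to compound 4 (1.90 log units; beyond the scatter), and among the compounds shown the decyl chain of compound 1 remains the only group giving a value in the low range.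

The compounds shown do not separate the contribution of the sulfonyl amino linker from that of the ring, which a carboxamide linker or a plain benzylamine arm would address. They also leave open whether chlorine or chain length governs the value of compound 3, a question that a plain propyl chain or a decyl chain ending in chlorine would bear on.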